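Fluoro for methyl on the core of compound 2

A few compounds are considered here, and "the series" means these few. Any claim that something is new, unique, unknown or untested is made for them only; others in the source may bear on it.

Among the compounds with values here, the two compounds measured so far share one core. Compound 1 `Cc1ccc2nc(C(=O)Nc3c(F)cc(-c4cccc(F)c4)cc3F)c(C)c(O)c2c1` carries a hydroxy group and gives 37.3% in a functional assay on Hep 3B2 cells (Homo sapiens) for antiproliferative activity, read by MTT assay, with a stated time of 24 h, tested at 33.33 ug/mL; a higher number here means a stronger effect of the compound at the concentration tested, a lower number a weaker effect. Compound 2 `Cc1ccc2nc(C(=O)Nc3c(F)cc(-c4cccc(F)c4)cc3F)c(C)c(C(=O)O)c2c1` carries a carboxy group in its place and gives 41.3% in this assay; the step of a number 4 percentage points higher from compound 1 to compound 2 (within the scatter) is within the scatter. Compound 2 thus holds the higher of the two numbers, but it cannot be told apart from compound 1 on this evidence.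

Compound 3 `Cc1c(C(=O)Nc2c(F)cc(-c3cccc(F)c3)cc2F)nc2ccc(F)cc2c1C(=O)O` has not yet been measured in this assay. Its difference from compound 2 is fluoro in place of methyl on an aromatic carbon. Within the data shown here, no measured step in this set concerns this kind of change; the only step available, carboxy in place of hydroxy, is at another place on the core and was itself within the scatter. The expectation is therefore a step of a number 0.3 percentage points lower from compound 2 to compound 3 (within the scatter) with no movement beyond the scatter. For compound 3 the estimated value is 41%, with a range from 27% to 55%.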

Compound 3, a percentage reported as inhibition, at one concentration (the size of the read-out at that concentration, not a potency): 34.3%
Compound 3: the middle estimate sits 6.7 percentage points above what was measured; low and high end bracket the measured number.
By their numbers in this assay, from the lowest: compounds 3, 1 and 2 (each within the scatter of the next).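

Within the data shown here, this is the first reading at this position of the shared core: fluoro in place of methyl on an aromatic carbon of the fused system gives a number 7 percentage points lower from compound 2 to compound 3 (within the scatter) in this assay. On this single pair, with the carboxy group kept, exchanging one heavy atom for another at this position produces no change that can be told apart from the scatter, so the methyl group is not shown to be needed for the read-out at the concentration tested. Nothing available on these compounds offers an explanation of this step.

As far as these compounds go, it remains open whether fluoro at this position would behave the same way with the hydroxy group of compound 1 in place of the carboxy group. Also open, from the compounds shown here alone, is whether a different group here, such as chloro, methoxy, an amine or a longer chain, would move the number beyond the scatter.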